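Chain change on compound 1: working notes

A few compounds are considered here, and "the series" means these few. Any claim that something is new, unique, unknown or untested is made for them only; others in the source may bear on it.

Measured so far in a functional assay on SW-620 cells (Homo sapiens) for cytotoxicity; on this read-out lower numbers stand for stronger inhibition and higher numbers for weaker inhibition:
- compound 1 `O=C(CCCCCCC(=O)Nc1nc2ccccc2s1)NO`: 4.01 ug/mL
- compound 2 `O=C(CCCCCCC(=O)Nc1nc2ccc([N+](=O)[O-])cc2s1)NO`: 0.29 ug/mL
- compound 3 `COc1ccc2nc(NC(=O)CCCCCCC(=O)NO)sc2c1`: 0.96 ug/mL

Compound 1 holds the highest number of the three, and so the weakest inhibition here. The nearest neighbour is a 4.2-fold lower number from compound 1 to compound 3 (0.62 log units; beyond the scatter) and the furthest is a 14-fold lower number from compound 1 to compound 2 (1.14 log units; beyond the scatter).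

The next compound is compound 4 `O=C(CCCCC(=O)Nc1nc2ccccc2s1)NO`, which keeps the core of compound 1 and alters only the chain: hydroxycarbamoyl in place of 2-(hydroxycarbamoyl)ethyl on a saturated chain carbon, four bonds along the chain from a carbonyl carbon.

Going by the values given here, no measured step touches the chain. All three are changes on an aromatic carbon, so they bear on this one only indirectly, as a guide to how far a single change can move this assay in this series. The largest is a 14-fold lower number from compound 1 to compound 2 (1.14 log units; beyond the scatter), while a 3.3-fold higher number from compound 2 to compound 3 (0.52 log units; beyond the scatter) is modest. All three lower or raise the number beyond the scatter, so a flat result is not assumed. The data give no direction for a chain change, and a higher number is a judgement call. A modest step is expected, with a large one possible. The expected change is a 3.0-fold higher number from compound 1 to compound 4 (0.48 log units; beyond the scatter). For compound 4 the estimated value is 12 ug/mL, with an expected range from 4 ug/mL to 40 ug/mL.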

Compound 4, half-maximal inhibitory concentration: 7.85 ug/mL
Beside the measured number, compound 4's estimate is 1.5-fold (0.18 log units) above it; the range from low to high includes it.
By their numbers in this assay, from the lowest: compound 2; then compound 3; then compounds 1 and 4 (each within the scatter of the next).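

The chain position now has its first reading, and the change from 2-(hydroxycarbamoyl)ethyl to hydroxycarbamoyl, on a saturated chain carbon four bonds along the chain from a carbonyl carbon, gives in this assay a 2.0-fold higher number from compound 1 to compound 4 (0.29 log units; within the scatter). Compounds 1 and 4 therefore cannot be told apart on this read-out, so this chain change does not resolve as an effect here. This differs from the aromatic changes, where the step with nitro is a 14-fold lower number from compound 1 to compound 2 (1.14 log units; beyond the scatter) and the step with methoxy is a 4.2-fold lower number from compound 1 to compound 3 (0.62 log units; beyond the scatter), and nothing available explains the result at this position.

Open, going by these compounds, is whether a chain longer than that of compound 1, or a carboxylic acid in place of hydroxycarbamoyl, would leave the number within the scatter as well. Also open is whether nitro or methoxy on an aromatic carbon of compound 4 would lower the number as they do on compound 1, since the compounds shown carry those groups only with the chain of compound 1.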